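A Single Chloro Added to Compound 2

The source may report more compounds than this note shows. Statements on the series, on what has been measured and on what is new or still open speak of the compounds shown alone.

Two compounds frame this step. In a functional assay on AGS cells (Homo sapiens) for antiproliferative activity, read by MTT assay, with a stated time of 48 h (a higher number here means a weaker inhibitor of growth, a lower number a stronger inhibitor of growth), compound 1 `COc1ccc(N(C)c2nc(Cl)nc3c2ncn3C)cc1` gives a measured 260 nM.

Compound 2 `COc1ccc(Cn2cnc3c(N(C)c4ccc(OC)cc4)ncnc32)cc1` yields no number in this assay, and its > 100000 nM is a limit of the assay.

The next compound, compound 3 `COc1ccc(Cn2cnc3c(N(C)c4ccc(OC)cc4)nc(Cl)nc32)cc1`, has not yet been measured. It departs from compound 2 in one place, chloro in place of hydrogen on an aromatic carbon, between two ring nitrogen atoms.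

No measured step sizes this change directly. The expectation rests on compound 1, which reaches 260 nM, so a large move towards stronger inhibition of growth is expected in this assay, rather than none beyond the scatter.

The expected change is an at least 33-fold lower number from compound 2 to compound 3 (1.52 log units; beyond the scatter).

For compound 3 the estimate is 3000 nM, with an expected range from 300 nM to 40000 nM.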

Compound 3, concentration for 50% growth inhibition: > 100000 nM
Compound 3: no number, only a limit; the forecaster's own chance of this, stated with the estimate: 15%; at least 33-fold (1.52 log units) between middle value and limit.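

In this assay, chloro on the aromatic carbon between two ring nitrogen atoms leaves compound 3 at a limit, > 100000 nM, not a number. The chloro step cannot be read because compound 2 and compound 3 both sit at the same limit: the limit of > 100000 nM in this assay, at which 2 of the 3 values shown sit. Among these compounds, with the chloro present in both compounds, 4-methoxyphenyl in place of hydrogen on a saturated chain carbon bound to an aromatic nitrogen gives an at least 380-fold higher number from compound 1 to compound 3 (2.58 log units; beyond the scatter), a large step that sizes this change for the first time.

From the compounds shown here alone, it remains open how far the inhibition of growth seen with compound 1 depends on the chloro, which an amine or a hydrogen at that carbon could test. Going by these compounds, it is also open whether a plain phenyl or a short ethyl chain in place of the 4-methoxybenzyl group would keep any of that inhibition.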